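The compounds below may be only part of what the source reports. "The series", "measured", "known", "first", "only" and "open" are said of these compounds alone.

Compound 1 `CN(C)Cc1ccc2nc(NC(=O)N/N=C/c3c[nH]c4ccccc34)sc2c1`: 1190 nM
Compound 2 `CN(C)Cc1ccc2nc(NC(=O)N/N=C/c3cn(Cc4cccc(Cl)c4)c4ccccc34)sc2c1`: 1140 nM

In a functional assay on MDA-MB-231 cells (Homo sapiens) for cytotoxicity, read by MTT assay, with a stated time of 72 h (a lower number here means a stronger inhibitor, a higher number a weaker inhibitor), compound 2 gives 1140 nM, which stands level with compound 1 within the scatter. Compound 3 `CN(C)Cc1ccc2nc(NC(=O)N/N=C/c3cn(Cc4ccc(Cl)c(Cl)c4)c4ccccc34)sc2c1` turns the 3-chlorobenzyl of compound 2 into 3,4-dichlorobenzyl: chloro in place of hydrogen on an aromatic carbon. The new chloro sits ortho to a chloro group and para to a large group.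

Among the measured compounds shown here, one measured step bears on this: a 1.0-fold lower number from compound 1 to compound 2 (0.02 log units; within the scatter). For the measured compounds named here, that step introduced the whole 3-chlorobenzyl group, and no measured step shows a chloro in the new place. Only a small change is therefore expected in this assay, with no direction beyond the scatter. The expected step is a 1.1-fold lower number from compound 2 to compound 3 (0.06 log units; within the scatter). For compound 3 the estimated value is 1000 nM, with an expected range of 480 nM to 2100 nM.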

Compound 3, half-maximal inhibitory concentration: 1000 nM
Estimate against measurement, compound 3: no gap at the digits printed, and the stated range covers the measured number.
By their numbers in this assay, from the lowest: compounds 3, 2 and 1 (each within the scatter of the next).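

In this assay, the new chloro, ortho to a chloro group and para to a large group, gives a step that stays within the scatter: a 1.1-fold lower number from compound 2 to compound 3 (0.06 log units; within the scatter). The full 3,4-dichlorobenzyl group on the aromatic nitrogen also gives only a 1.2-fold lower number from compound 1 to compound 3 (0.08 log units; within the scatter), so a second chloro on this benzyl group shifts the number no further than the first did. No measured evidence explains this result. The compounds shown leave open whether an amine or a carboxylic acid in place of this chloro would move the number beyond the scatter.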